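Cyano in Place of Fluoro: Expectation for Compound 3

A few compounds are considered here, and "the series" means these few. Any claim that something is new, unique, unknown or untested is made for them only; others in the source may bear on it.

For the measured compounds named here, compound 1 `Cc1ccc(C2=NN(c3nc(-c4ccc(F)cc4)cs3)C(c3ccc(F)cc3)C2)s1` holds the only number in a functional assay on A549 cells (Homo sapiens) for antiproliferative activity, read by XTT assay, with a stated time of 24 h (on this read-out higher numbers stand for weaker inhibition and lower numbers for stronger inhibition), where compound 1 gives 125 ug/mL. Compound 2 `Fc1ccc(-c2csc(N3N=C(c4ccc(Cl)s4)CC3c3ccc(F)cc3)n2)cc1` reaches only a limit of the assay, giving > 500 ug/mL in this assay. Going by the values given here, the single measured step, an at least 4.0-fold higher number from compound 1 to compound 2 (0.60 log units; beyond the scatter), concerns a different position and rests on the limit (the limit of > 500 ug/mL in this assay, at which 1 of the 2 values shown sits). Compound 3 `Cc1ccc(C2=NN(c3nc(-c4ccc(C#N)cc4)cs3)C(c3ccc(F)cc3)C2)s1` differs from compound 1 by cyano in place of fluoro on an aromatic carbon. Among the compounds with values here, no measured step bears on this change, so no direction follows from the data. Near compound 1, compound 3 is expected at 125 ug/mL (range 40 ug/mL to 400 ug/mL), a step of no change at the digits printed from compound 1 to compound 3 (within the scatter) expected to stay within the scatter.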

Compound 3, half-maximal inhibitory concentration: 322 ug/mL
Estimate against measurement, compound 3: 2.6-fold (0.41 log units) below; the measured number falls inside the stated range.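

In this assay, for the compounds shown here, going from 4-fluorophenyl to 4-cyanophenyl gives a 2.6-fold higher number from compound 1 to compound 3 (0.41 log units; beyond the scatter), so this position, on which no earlier step bore, does respond to a change, and fluoro is the better of the two groups here. Both single changes from compound 1 shown so far weaken inhibition, but their sizes cannot be set against each other, since compound 2 stands at a limit of the assay: the limit of > 500 ug/mL in this assay, at which 1 of the 3 values shown sits.

From the compounds shown here alone, whether the weakening belongs to cyano alone or to any replacement of fluoro stays open. Going by these compounds, how an amine or a carboxylic acid on this aromatic carbon would read also stays open.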